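Moving the Fluorine Around the Benzyl Ring

This account rests on a few compounds, and the source may have more. Where it says the series, first, only, none or still open, it means among the compounds named here.

Compound 1 `CCN1C(=O)S/C(=C\c2ccc(N)cc2)C1=O` gives 108000 nM in a functional assay on HeLa cells (Homo sapiens) for cytotoxicity, read by cell counting, with a stated time of 4 days; a lower number here means a stronger inhibitor, a higher number a weaker inhibitor.
Compound 3 `Nc1ccc(/C=C2\SC(=O)N(Cc3ccc(F)cc3)C2=O)cc1` gives 186000 nM in this assay.
Compound 2 `Nc1cccc(/C=C2\SC(=O)N(Cc3cccc(F)c3)C2=O)c1` gives in this assay only a limit, > 250000 nM.

Among the two plain numbers, compound 3 holds the higher one; its nearest neighbour is compound 1, with a 1.7-fold higher number from compound 1 to compound 3 (0.24 log units; within the scatter), so the two cannot be told apart. Compound 2 stands at the limit of > 250000 nM in this assay, at which 1 of the 3 values shown sits, and is a limit, not a number. The unmeasured compound 4 `Nc1ccc(/C=C2\SC(=O)N(Cc3cccc(F)c3)C2=O)cc1` differs from compound 3 by 3-fluorophenyl in place of 4-fluorophenyl on a saturated chain carbon bound to an amide-type nitrogen in a ring. Going by the values given here, no measured step covers this change; the single measured step, a 1.7-fold higher number from compound 1 to compound 3 (0.24 log units; within the scatter), concerns a different substituent and was itself within the scatter. Compound 4 is therefore expected to show a 1.1-fold higher number from compound 3 to compound 4 (0.03 log units; within the scatter), nothing beyond the scatter. The estimate for compound 4 is 200000 nM, between 90000 nM and 450000 nM.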

Compound 4, half-maximal inhibitory concentration: 250000 nM
Compound 4: middle estimate off by 1.3-fold (0.10 log units), on the low side; measured number inside the range.
By their numbers in this assay, from the lowest: compounds 1, 3 and 4 (each within the scatter of the next, the first and the last beyond it).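

In this assay, moving the fluorine on this carbon, with 3-fluorophenyl in place of 4-fluorophenyl, leaves the two compounds indistinguishable: a 1.3-fold higher number from compound 3 to compound 4 (0.13 log units; within the scatter). With 3-fluorophenyl in place of methyl at the same place, the series shows its first readable step beyond the scatter, though a modest one: a 2.3-fold higher number from compound 1 to compound 4 (0.36 log units; beyond the scatter). Compound 2 gives only a limit: the limit of > 250000 nM in this assay, at which 1 of the 4 values shown sits. That leaves one step that cannot be read (a number no higher from compound 2 to compound 4 (the limit leaves the size open)).

From the compounds shown here alone, it remains open whether a chlorine or a methoxy group in place of the fluorine would change the number. Going by these compounds, it also remains open whether any group at this place would give a stronger inhibitor than compound 1.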